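The source may hold more compounds than are shown below. What is called first, only, known or untested is meant among the compounds shown, and "the series" means these compounds.

Measured so far in an assay on isolated protein for inhibition of thiosulfate sulfurtransferase (Homo sapiens), with a stated time of 60 min, in the absence of a further agent; on this read-out higher numbers stand for weaker inhibition and lower numbers for stronger inhibition:
Compound 1 `O=C(Nc1cccc(Cl)c1)c1cc(Br)cc(Br)c1O` — compound 1 gives > 100000 nM, a limit of the assay.
Compound 2 `O=C(Nc1cccc(Cl)c1)c1ccccc1O` — compound 2 gives > 100000 nM, a limit of the assay.
Compound 3 `O=C(Nc1cccc(Cl)c1)c1cccc(Br)c1` — compound 3 gives > 100000 nM, a limit of the assay.

Compound 3 stands where every measured value of the series stands, at the limit of > 100000 nM in this assay, at which 3 of the 3 values shown sit; no number places it apart from compound 1 or compound 2. Among the compounds with values here, no step between measured compounds can be computed. Compound 4 `O=C(Nc1cccc(Cl)c1)c1cccc(Br)c1O` differs from compound 3 by hydroxy in place of hydrogen on an aromatic carbon. Since every measured compound sits at the limit, the expected step in this assay is a number no higher from compound 3 to compound 4 (the limit leaves the size open), none beyond the scatter, with a limit the most likely outcome. Compound 4 is estimated at 100000 nM in this assay, within a range of 30000 nM to 300000 nM.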

Compound 4, half-maximal inhibitory concentration: > 100000 nM
Compound 4 gave a limit, no number; the forecaster's own chance of this, stated with the estimate: 85%; the middle value sits exactly at the limit.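

No step can be read from compound 4 to compound 1, compound 2 or compound 3, since all four sit at a limit: the limit of > 100000 nM in this assay, at which 4 of the 4 values shown sit.

The compounds shown leave open whether any change to the shared core gives a readable number.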